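Moving a fluorine across a ring on two related cores

The source may hold more compounds than are shown below. What is called first, only, known or untested is meant among the compounds shown, and "the series" means these compounds.

Of the compounds shown here, three have been tested in a functional assay on OVCAR-3 cells (Homo sapiens) for antiproliferative activity, read by MTT assay, with a stated time of 24 h (a lower number here means a stronger inhibitor, a higher number a weaker inhibitor), and a fourth awaits its number. Compound 1 `O=C(NNc1ccccc1F)c1cccc(NS(=O)(=O)c2cnc(O)nc2O)c1` gives 17000 nM in this assay. Compound 2 `O=C(NNc1ccc(F)cc1)c1cccc(NS(=O)(=O)c2cnc(O)nc2O)c1` is reported in this assay only as a limit, > 20000 nM, rather than as a number. Compound 3 `O=C(NNc1ccccc1F)c1ccccc1NS(=O)(=O)c1cnc(O)nc1O` gives 9570 nM in this assay, and this is the lowest of the two numbers shown, with compound 1 nearest and within the scatter of it. Compound 4 `O=C(NNc1ccc(F)cc1)c1ccccc1NS(=O)(=O)c1cnc(O)nc1O` has not yet been measured in this assay.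

The difference between the core of compound 1 and the core of compound 3 is not broken down here. On both cores the same change is made: 4-fluorophenyl in place of 2-fluorophenyl on an amine nitrogen, and (4-fluorophenyl in place of 2-fluorophenyl on an amine nitrogen), and the surroundings of the place are described in the same words for both. Going by these compounds, on the core of compound 1 that change gave an at least 1.1-fold higher number from compound 1 to compound 2 (0.07 log units; that floor lies within the scatter), a step whose true size is unknown because the limit of > 20000 nM in this assay, at which 1 of the 3 values shown sits, caps what the assay reports.

For compound 4 the expectation rests on compound 1 moving to a limit in this assay, so a step of about a 1.7-fold higher number from compound 3 to compound 4 (0.22 log units; within the scatter) is estimated, with a real chance that the assay again returns only a limit. Compound 4 is therefore expected to give roughly 16000 nM, with a plausible range from 8000 nM to 30000 nM.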

Compound 4, half-maximal inhibitory concentration: > 20000 nM
Compound 4 ended at the assay's limit; the forecaster's own chance of this, stated with the estimate: 35%; middle value at least 1.2-fold (0.09 log units) away from the limit.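

In this assay, compound 4 is reported only as a limit, > 20000 nM. Putting 4-fluorophenyl in place of 2-fluorophenyl on the amine nitrogen therefore gives an at least 2.0-fold higher number from compound 3 to compound 4 (0.32 log units; beyond the scatter), so on this core the change clearly raises the number, and the real step may be larger still. This shows that the change weakens activity on the core of compound 3, while on the core of compound 1 the smallest possible step stays within the scatter, so it does not show that the change carries across cores with the same size, or that it fails to do so: the same change on two cores in this assay, an at least 1.1-fold higher number (0.07 log units; that floor lies within the scatter) from compound 1 to compound 2 and an at least 2.0-fold higher number (0.32 log units; beyond the scatter) from compound 3 to compound 4; the limit leaves it open whether they differ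

Going by these compounds, compound 2 and compound 4 sit at the same limit, so the two cores cannot be ranked when they carry 4-fluorophenyl, and how far beyond the limit either compound lies remains unknown: the limit of > 20000 nM in this assay, at which 2 of the 4 values shown sit. Also open is how the two cores would respond if the amine nitrogen carried a plain phenyl group or a chlorophenyl group instead of a fluorophenyl group.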